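From a Small Acid Side Chain to a Piperidine Acid

The compounds below may be only part of what the source reports. "The series", "measured", "known", "first", "only" and "open" are said of these compounds alone.

Compound 1 `COc1cccc([C@H]2O[C@H](CC(=O)N(C)CC(=O)O)C(=O)N(CC(C)(C)CO)c3ccc(Cl)cc32)c1OC` is tested in a functional assay on the whole organism for inhibition, with Rattus norvegicus as the target, at a dose of 10 mg/kg by the oral route (a lower number here means less inhibition, a higher number more inhibition at the dose given (going by the name of the read-out)), where compound 1 gives -1%, the lowest of the two numbers seen. Compound 2 `COc1cccc([C@H]2O[C@H](CC(=O)N3CCC(CC(=O)O)CC3)C(=O)N(CC(C)(C)COC(C)=O)c3ccc(Cl)cc32)c1OC` reaches 81% in this assay, far higher. Compound 3 `COc1cccc([C@H]2O[C@H](CC(=O)N3CCC(CC(=O)O)CC3)C(=O)N(CC(C)(C)CO)c3ccc(Cl)cc32)c1OC` gives 77%; 64% (2 entries) in this assay; its repeated readings the several entries of compound 3 in this assay, 77%; 64% (2 entries) lie close together. Going by the values given here, the path followed here leads from compound 1 to compound 4 `COc1cccc([C@H]2O[C@H](CC(=O)N3CCC(CCC(=O)O)CC3)C(=O)N(CC(C)(C)CO)c3ccc(Cl)cc32)c1OC`, not yet measured. 4-(2-carboxyethyl)piperidin-1-yl in place of (carboxymethyl)(methyl)amino on a carbonyl carbon No measured pair differs in exactly this way, so the step can only be anticipated. An upward step is expected because compound 2 gives 81% and compound 3 gives 77%; 64% (2 entries) while compound 1 sits near zero. The expected change is a number 66 percentage points higher from compound 1 to compound 4 (beyond the scatter). Compound 4 is estimated at 65%, within 35% to 90%.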

Compound 4, a percentage reported as inhibition, in the whole organism at one dose (the size of the read-out at that dose, not a potency): 76%
Compound 4: the middle estimate sits 11 percentage points below what was measured, and the stated range covers the measured number.
By their numbers in this assay, from the lowest: compound 1; then compounds 4 and 2 (each within the scatter of the next).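

With the rest of the molecule unchanged, the group on the carbonyl carbon decides the outcome in this assay: a number 77 percentage points higher from compound 1 to compound 4 (beyond the scatter). The hydrogen-bond donor and acceptor counts of the two groups match, so keeping these counts does not keep the inhibition, while the entering group brings a six-membered non-aromatic ring and more heavy atoms. Repeat readings in this test can still differ: the several entries of compound 3 in this assay, 77%; 64% (2 entries)

Open, from the compounds shown here alone, is whether the ring or the longer chain matters more. A piperidine without the carboxylic acid, or an open chain ending in that acid, would separate these two.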